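Swapping chloro for methyl on the aryl ring of compound 1

The source may hold more compounds than are shown below. What is called first, only, known or untested is meant among the compounds shown, and "the series" means these compounds.

Measured compounds:
- Compound 1, `Cc1cc(Cl)ccc1-c1cc2cc(CCC(=O)O)ccc2[nH]1`: 0.25 nM
- Compound 2, `O=C(O)CCc1ccc2[nH]c(-c3ccc(Cl)cc3C(F)(F)F)cc2c1`: a limit, > 25 nM

Among the measured compounds shown here, compound 1 is the only compound with a number in a functional assay on CHO cells for agonist activity at Free fatty acid receptor 1 (Homo sapiens), read by a luciferase reporter, with a stated time of 24 h; a higher number here means that more compound is needed for the effect, a lower number that less compound is needed; in this assay compound 1 gives 0.25 nM. For compound 2 this assay reports only a limit, > 25 nM, not a number; this is the limit of > 25 nM in this assay, at which 1 of the 2 values shown sits. For the measured compounds named here, the one measured step, an at least 100-fold higher number from compound 1 to compound 2 (2.00 log units; beyond the scatter), shows that changing a substituent on the six-membered ring can lower potency sharply.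

Compound 3, `Cc1ccc(-c2cc3cc(CCC(=O)O)ccc3[nH]2)c(C)c1`, is not yet measured. It differs from compound 1 as follows: methyl in place of chloro on an aromatic carbon. Going by the values given here, no measured step covers this particular swap, so the single step above gives only a warning that changes on this ring may matter, not a direction. Chloro and methyl are both small groups without donors or acceptors, so compound 3 is expected to stay close to compound 1, with a small step of a 2.4-fold higher number from compound 1 to compound 3 (0.38 log units; beyond the scatter). The estimate for compound 3 in this assay is 0.6 nM, with a range from 0.15 nM to 3 nM.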

Compound 3, half-maximal effective concentration: 0.41 nM
Compound 3: the middle estimate sits 1.5-fold (0.17 log units) above what was measured; the measured number falls inside the stated range.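

In this assay, placing methyl instead of chloro on the ring carbon para to a large group gives a step that cannot be told apart from repeat-measurement noise: a 1.6-fold higher number from compound 1 to compound 3 (0.21 log units; within the scatter). At this carbon, then, the two groups serve equally well in this assay, and the core of compound 1 keeps its very low number with either one. The earlier step concerned a different carbon of the same ring, so the sharp change seen there does not carry over to this position, though nothing shown gives a cause for either outcome.

From the compounds shown here alone, what remains open is whether this carbon would accept a group of a different kind, such as an amine, a nitrile or a methoxy group. Going by these compounds, it is also open whether any group is needed here at all, since a plain hydrogen at this carbon would answer that.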